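From Furan to Triazole in a Pair of Amide Agonists

A few compounds are considered here, and "the series" means these few. Any claim that something is new, unique, unknown or untested is made for them only; others in the source may bear on it.

Of the compounds shown here, two have been measured in an assay on HEK293 cells for agonist activity at transient receptor potential cation channel subfamily M member 8 (Homo sapiens), read by fluorescence and calcium flux, with a stated time of 15 min; on this read-out higher numbers stand for an effect only at larger amounts of compound and lower numbers for an effect already at smaller amounts. Compound 1 `CCN(Cc1ccoc1)C(=O)COc1ccc(C)cc1` gives 136 nM in this assay, the highest of the two numbers; compound 2 `Cc1ccc(OCC(=O)N(Cc2cccs2)C(C)C)cc1` gives 70 nM, and the gap between compound 1 and compound 2 lies within the usual scatter, so the two stand together.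

Compound 3 `CCN(Cc1c[nH]nn1)C(=O)COc1ccc(C)cc1` has not been measured in this assay. It differs from compound 1 in one place: 1H-1,2,3-triazol-4-yl in place of furan-3-yl on a saturated chain carbon bound to an amide-type nitrogen. For the measured compounds named here, no measured pair shows this kind of change, so its effect is not known from the data here.

Because compound 1 sits at 136 nM and the replacement introduces a hydrogen-bond donor where compound 1 had none, the writer expects a step of a 3.3-fold higher number from compound 1 to compound 3 (0.52 log units; beyond the scatter) toward a higher number, beyond the scatter. Compound 3 is therefore estimated at 450 nM in this assay, with a range from 120 nM to 1800 nM.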

Compound 3, half-maximal effective concentration: 31100 nM
For compound 3 the middle estimate is 69-fold (1.84 log units) below the measured one, and the stated range ends below it.
By their numbers in this assay, from the lowest: compounds 2 and 1 (each within the scatter of the next); then compound 3.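

For the compounds shown here, putting 1H-1,2,3-triazol-4-yl in place of furan-3-yl on a saturated chain carbon bound to an amide-type nitrogen gives a 230-fold higher number from compound 1 to compound 3 (2.36 log units; beyond the scatter) in this assay, the only step here between compounds that differ in one place, and it shows that this position does not accept every five-membered aromatic ring alike. The two rings match in their 5 heavy atoms and in carrying no net charge, yet they part in their hetero atoms and in the hydrogen-bond donor that enters, so counts of ring size alone do not predict the outcome here. Nothing measured here bears on why the step is so large.

The compounds shown leave open whether the large step belongs to the triazole ring as a whole or to its ring hydrogen, which a methyl group on the triazole nitrogen could separate. They also leave open where rings such as oxazole or imidazole would fall at this position.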